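Bromo for methoxy on a thiazoloimidazole hydrazide

A few compounds are considered here, and "the series" means these few. Any claim that something is new, unique, unknown or untested is made for them only; others in the source may bear on it.

Compound 1 `COc1ccc(-c2c(CN3CCCCC3)nc3scc(C(=O)O)n23)cc1` and compound 2 `O=C(O)c1csc2nc(CN3CCCCC3)c(-c3ccc(Br)cc3)n12` share one core; compound 3 `COc1ccc(-c2cnc3scc(C(=O)NNC(C)=O)n23)cc1` and compound 4 `CC(=O)NNC(=O)c1csc2ncc(-c3ccc(Br)cc3)n12` share another, and the difference between the two cores is not broken down here. In a functional assay on HepG2 cells (Homo sapiens) for antiproliferative activity, read by MTT assay, with a stated time of 72 h (a higher number here means a weaker inhibitor, a lower number a stronger inhibitor), compound 1 gives 75100 nM. Compound 2 reaches only the limit > 100000 nM in this assay, where (the limit of > 100000 nM in this assay, at which 1 of the 3 values shown sits). The change bromo in place of methoxy on an aromatic carbon thus gave an at least 1.3-fold higher number from compound 1 to compound 2 (0.12 log units; that floor lies within the scatter). Compound 3 gives 11800 nM in this assay. The same change, (bromo in place of methoxy on an aromatic carbon), is made from compound 3 to compound 4. Since that change from compound 1 to compound 2 gave an at least 1.3-fold higher number from compound 1 to compound 2 (0.12 log units; that floor lies within the scatter), a floor within the scatter, a small upward step is expected, a 1.5-fold higher number from compound 3 to compound 4 (0.18 log units; within the scatter). Compound 4 is therefore estimated at 18000 nM in this assay, likely between 7000 nM and 50000 nM.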

Compound 4, half-maximal inhibitory concentration: 3480 nM
The estimate for compound 4 lay 5.2-fold (0.71 log units) above the measured number, and the stated range ends above it.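

In this assay, bromo in place of methoxy on an aromatic carbon gave a 3.4-fold lower number from compound 3 to compound 4 (0.53 log units; beyond the scatter), so the change did not carry over unchanged from one core to the other: the same change on two cores in this assay, an at least 1.3-fold higher number (0.12 log units; that floor lies within the scatter) from compound 1 to compound 2 and a 3.4-fold lower number (0.53 log units; beyond the scatter) from compound 3 to compound 4, at least 4.5-fold (0.65 log units) apart, beyond the scatter of two such steps. The value of compound 2 is a limit and not a number, which leaves the step on its core known only as a floor: the limit of > 100000 nM in this assay, at which 1 of the 4 values shown sits. Which part of the two cores accounts for the gap is not shown, and two pairs set no rule for the series.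

The compounds shown leave open how chloro or an amine would compare with bromo and methoxy on that aromatic carbon. They also leave open whether the step from compound 3 to compound 4 would hold with a longer chain in place of the acetyl group.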